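The source may report more compounds than this note shows. Statements on the series, on what has been measured and on what is new or still open speak of the compounds shown alone.

Compound 1 `Cc1cc(C)c(CN2CCc3c(Cl)cc([C@H](CO)[C@@H]4CCCO4)c(Cl)c3C2=O)c(=O)[nH]1` gives 400000 nM in a physicochemical assay for solubility, measured as kinetic solubility (a lower number here means a less soluble compound, a higher number a more soluble compound), and one further entry for it carries no single number. Among the measured compounds shown here, the only other measured compound, compound 2 `Cc1cc(C)c(CN2CCc3c(Cl)cc(C(CO)C4CCOC4)c(Cl)c3C2=O)c(=O)[nH]1`, gives 522000 nM; 508000 nM (2 entries), and its repeat entries agree closely (the several entries of compound 2 in this assay, 522000 nM; 508000 nM (2 entries)). The values of these two compounds lie within the usual scatter of each other. Compound 3 `Cc1cc(C)c(CN2CCc3c(Cl)cc([C@@H](C)CO)c(Cl)c3C2=O)c(=O)[nH]1` keeps the core of compound 1 but has methyl in place of oxolan-2-yl on a saturated chain carbon bound to an aromatic carbon and a saturated chain carbon. For the measured compounds named here, no measured step covers this exchange, so the expectation starts from compound 1 at 400000 nM: a small downward step in this assay, probably within the scatter. The expected change is a 1.3-fold lower number from compound 1 to compound 3 (0.12 log units; within the scatter). Compound 3 is estimated at 300000 nM, with an expected range of 120000 nM to 600000 nM.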

Compound 3, solubility: 143000 nM
Compound 3: middle estimate off by 2.1-fold (0.32 log units), on the high side; low and high end bracket the measured number.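

In this assay, among the compounds shown here, methyl in place of oxolan-2-yl on a saturated chain carbon bound to an aromatic carbon and a saturated chain carbon gives a 2.8-fold lower number from compound 1 to compound 3 (0.45 log units; beyond the scatter), the first readable step at this position. The read-out at this place therefore responds to the group it carries: the step is modest but lies beyond the scatter. Repeat entries in this assay can agree closely, which lends some weight to a step of this size: the several entries of compound 2 in this assay, 522000 nM; 508000 nM (2 entries).

This single exchange removes the ring and its oxygen together, so the compounds shown cannot separate the contribution of either one. On these data alone, whether a cyclopentyl group or a methoxymethyl chain at the same place would behave like oxolan-2-yl or like methyl remains open.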